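The source may hold more compounds than are shown below. What is called first, only, known or untested is meant among the compounds shown, and "the series" means these compounds.

Working notes on the series. Compound 1 `O=C(/C=C/c1ccc2c(c1)B(O)OC2)c1ccc(F)cc1` gives 1400 nM in a functional assay on SK-OV-3 cells (Homo sapiens) for cytotoxicity, read by MTT assay, with a stated time of 48 h; a higher number here means a weaker inhibitor, a lower number a stronger inhibitor; compound 2 `Nc1ccc(C(=O)/C=C/c2ccc3c(c2)B(O)OC3)cc1` gives 20200 nM; compound 3 `O=C(/C=C/c1ccc2c(c1)B(O)OC2)c1cccc(F)c1` gives 4800 nM. Compound 3 stands second highest of the three numbers: a 3.4-fold higher number from compound 1 to compound 3 (0.54 log units; beyond the scatter), and a 4.2-fold lower number from compound 2 to compound 3 (0.62 log units; beyond the scatter).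

Compound 4 `COCOc1cccc(C(=O)/C=C/c2ccc3c(c2)B(O)OC3)c1` differs from compound 3 by methoxymethoxy in place of fluoro on an aromatic carbon. Going by the values given here, no measured step swaps fluoro for methoxymethoxy, so the bearing steps are indirect. The nearest is a 14-fold higher number from compound 1 to compound 2 (1.16 log units; beyond the scatter), where fluoro on the 4-fluorophenyl of compound 1 gave way to an uncharged group; that step was large and in the weakening direction. The positional step a 3.4-fold higher number from compound 1 to compound 3 (0.54 log units; beyond the scatter) shows the 3-fluorophenyl of compound 3 already sits well above compound 1. Taken together, replacing fluoro on the 3-fluorophenyl with a larger group bearing two hydrogen-bond acceptors is expected to weaken in this assay, by a modest to large step, with wide uncertainty since no direct analogue exists.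

Compound 4 is therefore estimated at 11000 nM, in the range 3500 nM to 40000 nM. The expected step is a 2.3-fold higher number from compound 3 to compound 4 (0.36 log units; beyond the scatter).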

Compound 4, half-maximal inhibitory concentration: 11700 nM
Compound 4: middle estimate off by 1.1-fold (0.03 log units), on the low side; the measured number falls inside the stated range.
By their numbers in this assay, from the lowest: compound 1; then compound 3; then compounds 4 and 2 (each within the scatter of the next).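

In this assay, going by these compounds alone, this is the first step that exchanges one group for another while the place stays fixed, meta to a large group: a 2.4-fold higher number from compound 3 to compound 4 (0.39 log units; beyond the scatter). Methoxymethoxy, with 4 heavy atoms against 1 for fluoro, gives a modest step here, whereas the exchange on the 4-fluorophenyl of compound 1 was large, a 14-fold higher number from compound 1 to compound 2 (1.16 log units; beyond the scatter), though that step involves a different entering group and a different place. Nothing measured here accounts for the step from compound 3 to compound 4.

Going by these compounds, it remains open whether the higher number follows from the loss of fluoro or from the entry of methoxymethoxy, and whether the same exchange would give a similar step on the 4-fluorophenyl. A hydroxyl, a methoxy or an amine at this same place would help separate these readings.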